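The compounds below may be only part of what the source reports. "The series", "measured", "known", "first", "only" and "open" are said of these compounds alone.

Series notes. Compound 1 `Nc1ccccc1NC(=O)CCCNCC(=O)Nc1ccc(Br)cc1` is tested in a functional assay on the whole organism (Ehrlich cells, Mus musculus) for antiproliferative activity, with a stated time of 24 h, at a dose of 0.2 mmol/kg by the intraperitoneal route (on this read-out lower numbers stand for less inhibition and higher numbers for more inhibition at the one dose given (going by the name of the read-out)), and gives 68.7%. Compound 2 `COc1ccc(NC(=O)CNc2ccc(C(=O)Nc3ccccc3N)cc2)cc1` in this assay gives 62.3%. Among the compounds with values here, of the two numbers so far, compound 1 carries the higher one, but its gap to compound 2 lies within the usual scatter, so the two cannot be told apart on these data.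

Compound 3 `COc1ccc(NC(=O)CNCCCC(=O)Nc2ccccc2N)cc1` has not been measured. Against compound 1 it differs as follows: methoxy in place of bromo on an aromatic carbon. Within the data shown here, no pair of measured compounds shows this exchange on its own, so there is no measured step to lean on. Compound 2 already carries the methoxy on its end-ring and sits close to compound 1, which gives no sign that the exchange moves the read-out much. The step from a number 5.7 percentage points lower from compound 1 to compound 3 (within the scatter) is therefore expected to be small, toward slightly less inhibition or none beyond the scatter. For compound 3 in this assay the estimate is 63%, between 48% and 76%.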

Compound 3, a percentage reported as inhibition, in the whole organism at one dose (the size of the read-out at that dose, not a potency): 63.3%
For compound 3 the middle estimate is 0.3 percentage points below the measured one, within the range that was stated.
By their numbers in this assay, from the lowest: compounds 2, 3 and 1 (each within the scatter of the next).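

In this assay the exchange of 4-bromophenyl for 4-methoxyphenyl can now be read directly as a single change (a number 5.4 percentage points lower from compound 1 to compound 3 (within the scatter)). At this aromatic carbon, para to a large group, bromo and methoxy cannot be told apart at the one dose given, so on this core the inhibition seen with compound 1 does not depend on bromo rather than methoxy. No measurement of any property of these compounds bears on this result.

Going by these compounds, whether an amine or a carboxylic acid on this same carbon would shift the read-out beyond the scatter stays open. Also open, on these data alone, is whether the exchange of bromo for methoxy would read the same way on a core with a longer chain.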